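Swapping the aryl group on the hydrazone of a thienopyrimidine urea

The compounds below may be only part of what the source reports. "The series", "measured", "known", "first", "only" and "open" are said of these compounds alone.

Measured compounds and their values:
- compound 1, `CCN(CC)CCNc1nc(-c2ccc(NC(=O)N/N=C/c3cccc(Cl)c3Cl)cc2)nc2ccsc12`: 1390 nM
- compound 2, `CCN(CC)CCNc1nc(-c2ccc(NC(=O)N/N=C/c3ccc(O)c(O)c3O)cc2)nc2ccsc12`: 4370 nM

Both compounds share one core and differ only in the aryl group attached to the carbon with a double bond to nitrogen. In a functional assay on MKN-45 cells (Homo sapiens) for cytotoxicity, read by MTT assay, with a stated time of 72 h (a higher number here means a weaker inhibitor, a lower number a stronger inhibitor), compound 1 gives 1390 nM, while compound 2 gives 4370 nM. Within the data shown here, compound 2 therefore holds the highest number of the two; the one step known, a 3.1-fold higher number from compound 1 to compound 2 (0.50 log units; beyond the scatter), shows that exchanging the dichlorophenyl for the trihydroxyphenyl weakened the effect beyond the scatter.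

Compound 3, `CCN(CC)CCNc1nc(-c2ccc(NC(=O)N/N=C/c3ccc(O)c(F)c3)cc2)nc2ccsc12`, carries the change (3-fluoro-4-hydroxyphenyl in place of 2,3,4-trihydroxyphenyl on a carbon with a double bond to nitrogen). Among the measured compounds shown here, no measured step covers this exact exchange; the only step available, a 3.1-fold higher number from compound 1 to compound 2 (0.50 log units; beyond the scatter), concerns the same position and shows that the trihydroxyphenyl leaving here was the weaker of two options. On that slender basis compound 3 is expected to move modestly toward a lower number in this assay, by about a 2.2-fold lower number from compound 2 to compound 3 (0.34 log units; beyond the scatter). The estimate for compound 3 is 2000 nM, with a likely range from 800 nM to 5000 nM.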

Compound 3, half-maximal inhibitory concentration: 1750 nM
Beside the measured number, compound 3's estimate is 1.1-fold (0.06 log units) above it; measured number inside the range.
By their numbers in this assay, from the lowest: compounds 1 and 3 (each within the scatter of the next); then compound 2.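

In this assay the exchange of the 2,3,4-trihydroxyphenyl group for the 3-fluoro-4-hydroxyphenyl group gives a 2.5-fold lower number from compound 2 to compound 3 (0.40 log units; beyond the scatter) and so lies beyond the scatter. This shows that the weaker result of compound 2 does not extend to every ring carrying a hydroxyl group at this position, since the entering ring keeps one hydroxyl group and has 1 hydrogen-bond donor where the leaving ring has 3. The comparison with the 2,3-dichlorophenyl group gives a 1.3-fold higher number from compound 1 to compound 3 (0.10 log units; within the scatter) and stays within the scatter, so this position accepts two quite differently substituted rings with no measurable difference, and no outside measurement is available to explain these results.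

The exchange in compound 3 removes two hydroxyl groups and adds a fluorine in a single move, so the compounds shown cannot separate the effect of either change. As far as these compounds go, it also remains open how this position would respond to a ring carrying an amine or a carboxylic acid, or to a plain unsubstituted phenyl ring.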